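Step from an inactive pyridinyl analogue to a bicyclic replacement

The source may hold more compounds than are shown below. What is called first, only, known or untested is meant among the compounds shown, and "the series" means these compounds.

Measured compounds:
- compound 1, `Cc1c(-c2cc(Cl)cc(Cl)c2)c(C(=O)O)nn1-c1nc(-c2cc(Cl)cc(Cl)c2)c(SC(C)C)s1`: 2000 nM
- compound 2, `Cc1ccc(-c2c(C)nn(-c3nc(-c4ccc(Cl)c(Cl)c4)c(SC(C)C)s3)c2C(=O)O)cc1`: 3800 nM
- compound 3, `Cc1c(-c2cc(Cl)cc(Cl)c2)c(C(=O)O)nn1-c1nc(-c2ccncc2)c(SC(C)C)s1`: "not active" (no number reported)

In a functional assay on BJAB cells (Homo sapiens) for antiproliferative activity, with a stated time of 4 days (on this read-out higher numbers stand for an effect only at larger amounts of compound and lower numbers for an effect already at smaller amounts), compound 1 gives 2000 nM and compound 2 gives 3800 nM. Compound 3 is reported in this assay only as "not active" (no number reported), with no number attached, so there is no value from which a step to a neighbouring compound could be measured. Compound 3 thus stands apart from compound 1 and compound 2, which both carry a dichlorophenyl group where compound 3 carries pyridin-4-yl.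

Compound 4, `Cc1c(-c2cc(Cl)cc(Cl)c2)c(C(=O)O)nn1-c1nc(-c2ccc3nccn3c2)c(SC(C)C)s1`, differs from compound 3 in one place: a group of 9 heavy atoms (7 carbon, 2 nitrogen; one five-membered aromatic ring with 2 hetero atoms, one six-membered aromatic ring with 1 hetero atom) in place of a group of 6 heavy atoms (5 carbon, 1 nitrogen; one six-membered aromatic ring with 1 hetero atom), on an aromatic carbon. Among the measured compounds shown here, no measured pair in this set carries a comparable change, so no size can be given for this step from the data. Since compound 3 has no number, the step cannot be sized at all; what can be said is that compound 1 and compound 2 show the core can reach a measurable value once the group at this position is not pyridin-4-yl. Compound 4 is estimated to give 10000 nM in this assay, within a range of 2000 nM to 50000 nM, with a real chance that it too is reported only as inactive.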

Compound 4, half-maximal effective concentration: "not active" (no number reported)
For compound 4 the study gives words and no number, so the estimate cannot be set against anything.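

In this assay, among the compounds shown here, compound 3 and compound 4 are both reported only as not active, so no step between them can be read. No supporting measurement bears on this result. The compounds shown leave open whether any group other than dichlorophenyl at this position gives a measurable value.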